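Swapping the amine substituent on the piperidine ring

The source may report more compounds than this note shows. Statements on the series, on what has been measured and on what is new or still open speak of the compounds shown alone.

Measured so far:
compound 1 `c1ccc(CNCC2CCN(CCCc3c[nH]c4ccc(-n5cnnc5)cc34)CC2)cc1` — 1.6 nM
compound 2 `CC(C)=CCCN(C)C1CCN(CCCc2c[nH]c3ccc(-n4cnnc4)cc23)CC1` — 2.6 nM

Both compounds were tested in an assay on CHO cells for displacement of a labelled ligand from 5-hydroxytryptamine receptor 1D (Homo sapiens); on this read-out higher numbers stand for weaker inhibition and lower numbers for stronger inhibition. Compound 1 gives 1.6 nM and compound 2 gives 2.6 nM. Compound 2 has the higher of the two numbers, but the step of a 1.6-fold higher number from compound 1 to compound 2 (0.21 log units; within the scatter) is within the scatter, so the two compounds cannot be told apart on these data.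

Compound 3 `CC(=O)Nc1ccc(CN(C)C2CCN(CCCc3c[nH]c4ccc(-n5cnnc5)cc34)CC2)cc1` is the next compound. Compared with compound 2 the change is 4-acetamidophenyl in place of 3-methylbut-2-en-1-yl on a saturated chain carbon bound to an amine nitrogen. The amine attached to the saturated ring thus keeps its methyl and exchanges its chain-like arm for a benzyl arm carrying an acetamide.

For the measured compounds named here, only one measured step bears on this, namely the exchange of the whole amine arm from compound 1 to compound 2, which was a 1.6-fold higher number from compound 1 to compound 2 (0.21 log units; within the scatter). That a very different arm left the number essentially unchanged suggests that the arm on this amine is not a strong lever here, although a single step is a thin basis. Compound 3 is therefore expected to sit close to compound 2, with a 1.2-fold lower number from compound 2 to compound 3 (0.07 log units; within the scatter) as the expected step, and an estimated value of 2.2 nM, within 0.6 nM to 8 nM.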

Compound 3, half-maximal inhibitory concentration: 19 nM
Compound 3: middle estimate off by 8.6-fold (0.94 log units), on the low side; the measured number lies above the stated range.
By their numbers in this assay, from the lowest: compounds 1 and 2 (each within the scatter of the next); then compound 3.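

In this assay, the arm on this amine can move the number after all: 4-acetamidobenzyl in place of 4-methylpent-3-en-1-yl gives a 7.3-fold higher number from compound 2 to compound 3 (0.86 log units; beyond the scatter), a modest step but one beyond the scatter, whereas the earlier exchange of arm, a 1.6-fold higher number from compound 1 to compound 2 (0.21 log units; within the scatter), stayed within it. This place, a saturated chain carbon bound to an amine nitrogen, therefore does not treat every group alike, and the entering 4-acetamidophenyl group, with its six-membered aromatic ring of carbon only and its hydrogen-bond donor and acceptor, is the one arm shown that separates from the others. No measurement available here explains why this exchange weakens inhibition.

The compounds shown leave open whether the aromatic ring or the acetamide accounts for the step, and a plain benzyl arm on the same methylated amine would help separate the two. On these data alone, it also remains open whether a different group in the acetamide's place on the phenyl ring, such as a methoxy group, an amine or a carboxylic acid, would give a number closer to that of compound 2.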